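This account rests on a few compounds, and the source may have more. Where it says the series, first, only, none or still open, it means among the compounds named here.

Measured in a functional assay on A549 cells (Homo sapiens) for cytotoxicity, read by MTT assay, with a stated time of 48 h; a higher number here means a weaker inhibitor, a lower number a stronger inhibitor:
- compound 1 `O=c1ccoc2cc(OCc3cn(Cc4ccc([N+](=O)[O-])cc4)nn3)ccc12` gives > 100000 nM, a limit of the assay rather than a number.
- compound 2 `O=c1ccoc2cc(OCc3cn(Cc4ccccc4Br)nn3)ccc12` gives > 100000 nM, again only a limit.
- compound 3 `O=c1ccoc2cc(OCc3cn(Cc4cccc(Br)c4)nn3)ccc12` gives > 100000 nM, also a limit.

All three share one core and differ only in the group on a saturated chain carbon bound to an aromatic nitrogen. Because every value sits at the limit of > 100000 nM in this assay, at which 3 of the 3 values shown sit, none of the comparisons among them can be read: the change from compound 1 to compound 2 gives a step that the two limits leave unreadable from compound 1 to compound 2, from compound 1 to compound 3 a step that the two limits leave unreadable from compound 1 to compound 3, and from compound 2 to compound 3 a step that the two limits leave unreadable from compound 2 to compound 3. Compound 3 therefore stands nowhere distinct; it is simply one of three compounds that never reached a measurable half-maximal inhibitory concentration.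

Compound 4 `COc1ccc(Cn2cc(COc3ccc4c(=O)ccoc4c3)nn2)cc1` is the next variation on the same position: 4-methoxyphenyl in place of 3-bromophenyl on a saturated chain carbon bound to an aromatic nitrogen. Going by the values given here, no measured step bears on this change, so there is no basis to expect it to lift activity out of the unreadable region. The expected step is a number no higher from compound 3 to compound 4 (the limit leaves the size open), meaning no change that the scatter could reveal. Compound 4 is estimated to give 100000 nM, with a range from 30000 nM to 300000 nM.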

Compound 4, half-maximal inhibitory concentration: 16500 nM
Compound 4: the middle estimate sits 6.1-fold (0.78 log units) above what was measured; the measured number lies below the stated range.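

The group on a saturated chain carbon bound to an aromatic nitrogen can move the read-out after all: in this assay, the 4-methoxyphenyl group gives a readable half-maximal inhibitory concentration, where the 2-bromophenyl, 3-bromophenyl and 4-nitrophenyl groups gave none. The change shows as an at least 6.0-fold lower number from compound 3 to compound 4 (0.78 log units; beyond the scatter), as an at least 6.0-fold lower number from compound 2 to compound 4 (0.78 log units; beyond the scatter) and, with methoxy in place of nitro, as an at least 6.0-fold lower number from compound 1 to compound 4 (0.78 log units; beyond the scatter), and each size is only a floor, as one end of every pair is a limit and not a number. The comparisons among compound 1, compound 2 and compound 3 still cannot be read, and those three remain together at one limit: the limit of > 100000 nM in this assay, at which 3 of the 4 values shown sit.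

Compound 4 alone cannot tell whether the methoxy group brings the gain or whether the bromine and nitro groups hold the number back, and a plain phenyl group at this place would help separate those two readings. Going by these compounds, whether an amine or a carboxylic acid on that ring, or a longer chain between the ring and the aromatic nitrogen, would lower the number further also stays open.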